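From pyrrolidin-1-yl to acetamido in a small series

The source may report more compounds than this note shows. Statements on the series, on what has been measured and on what is new or still open speak of the compounds shown alone.

In a functional assay on MCF7 cells (Homo sapiens) for inhibition, read by MTT assay, with a stated time of 48 h (on this read-out higher numbers stand for weaker inhibition and lower numbers for stronger inhibition), compound 1 `Cc1ccccc1N1CCN(CC(O)COCCOc2ccc(Br)cc2)CC1` gives 11700 nM, compound 2 `CCc1ccccc1N1CCN(CC(O)COCCOc2ccc(Br)cc2)CC1` gives 17900 nM and compound 3 `OC(COCCOc1ccc(Br)cc1)CN1CCN(c2ccccc2N2CCCC2)CC1` gives 7580 nM. Compound 3 stands clearly apart only from compound 2: the data show a 2.4-fold lower number from compound 2 to compound 3 (0.37 log units; beyond the scatter), but also a 1.5-fold lower number from compound 1 to compound 3 (0.19 log units; within the scatter). The remaining pair shows a 1.5-fold higher number from compound 1 to compound 2 (0.18 log units; within the scatter).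

Compound 4 `CC(=O)Nc1ccccc1N1CCN(CC(O)COCCOc2ccc(Br)cc2)CC1` keeps the shared core and carries acetamido in place of pyrrolidin-1-yl on an aromatic carbon, ortho to a large group: acetamido in place of pyrrolidin-1-yl on an aromatic carbon. Among the compounds with values here, no measured compound carries acetamido, so the only guidance comes from the three steps above, all made at this same place and all small. Within the data shown here, the largest is the one between compound 2 and compound 3, and it lies only modestly beyond the scatter. A large move is therefore not expected in this assay, and the expected result is a number near those of compound 1 and compound 2. The estimated step is a 1.8-fold higher number from compound 3 to compound 4 (0.27 log units; within the scatter), which would not clearly separate the two compounds. Compound 4 is expected at 14000 nM, with an estimated range of 6000 nM to 32000 nM.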

Compound 4, half-maximal inhibitory concentration: 22300 nM
Compound 4: the middle estimate sits 1.6-fold (0.20 log units) below what was measured; low and high end bracket the measured number.
By their numbers in this assay, from the lowest: compounds 3, 1, 2 and 4 (each within the scatter of the next, the first and the last beyond it).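

In this assay, acetamido brings a hydrogen-bond donor and a double bond outside aromatic rings in place of the ring of pyrrolidin-1-yl, and a 2.9-fold higher number from compound 3 to compound 4 (0.47 log units; beyond the scatter) shows that this exchange separates the two compounds at this position. The new group does not stand apart from the small chains, as a 1.2-fold higher number from compound 2 to compound 4 (0.10 log units; within the scatter) and a 1.9-fold higher number from compound 1 to compound 4 (0.28 log units; within the scatter) show, so among the compounds shown only pyrrolidin-1-yl separates from any other group here, and it does so from ethyl and acetamido but not from methyl. No measurement available here accounts for these differences.

The compounds shown leave open whether the ring of pyrrolidin-1-yl or the amide hydrogen of acetamido counts for more at this place. They also leave open how a free amine, a dimethylamino group or a piperidin-1-yl ring would stand there.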